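A few compounds are considered here, and "the series" means these few. Any claim that something is new, unique, unknown or untested is made for them only; others in the source may bear on it.

Three compounds with a shared core, differing only in the aromatic ring on the double-bonded chain carbon bound to a double-bonded ring carbon, have been tested in a functional assay on A549 cells (Homo sapiens) for antiproliferative activity, read by MTT assay; a lower number here means a stronger inhibitor, a higher number a weaker inhibitor. Compound 1 `Cc1cccc(/C=C2/SC(N3CCC[C@H]3C(=O)Nc3ccc4ncnc(Nc5cccc(Cl)c5)c4c3)=NC2=O)n1` gives 8500 nM, and compound 2 `O=C1N=C(N2CCC[C@H]2C(=O)Nc2ccc3ncnc(Nc4cccc(Cl)c4)c3c2)S/C1=C/c1cccnc1` gives 10400 nM; the change between them, a 1.2-fold higher number from compound 1 to compound 2 (0.09 log units; within the scatter), stays within the scatter. For compound 3 `O=C1N=C(N2CCC[C@H]2C(=O)Nc2ccc3ncnc(Nc4cccc(Cl)c4)c3c2)S/C1=C/c1cccc(Br)c1` the assay reports only a limit, > 50000 nM. The two steps that lead to it, an at least 5.8-fold higher number from compound 1 to compound 3 (0.76 log units; beyond the scatter) and an at least 4.8-fold higher number from compound 2 to compound 3 (0.68 log units; beyond the scatter), both go beyond the scatter, so compound 3 stands as the weakest of the three, its value being (the limit of > 50000 nM in this assay, at which 1 of the 3 values shown sits). Compound 4 `O=C1N=C(N2CCC[C@H]2C(=O)Nc2ccc3ncnc(Nc4cccc(Cl)c4)c3c2)S/C1=C/c1ccccc1[N+](=O)[O-]` is not yet measured; it differs from compound 3 by 2-nitrophenyl in place of 3-bromophenyl on a double-bonded chain carbon bound to a double-bonded ring carbon. Within the data shown here, none of the measured steps involves the 2-nitrophenyl group, so its effect can only be guessed from the fact that the three measured values all sit at the weak end. The step of an at least 1.4-fold lower number from compound 3 to compound 4 (0.15 log units; that floor lies within the scatter) is therefore estimated to stay within the scatter, with a real chance that a limit is reported again. Compound 4 is expected to give about 35000 nM, in a range from 8000 nM to 150000 nM.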

Compound 4, half-maximal inhibitory concentration: > 50000 nM
Compound 4: only a limit was reported; the forecaster's own chance of this, stated with the estimate: 50%; middle value at least 1.4-fold (0.15 log units) from the limit.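

In this assay compound 4 gives > 50000 nM, which is a limit and not a number. Both steps from the compounds carrying a pyridine ring go beyond the scatter, an at least 5.8-fold higher number from compound 1 to compound 4 (0.76 log units; beyond the scatter) and an at least 4.8-fold higher number from compound 2 to compound 4 (0.68 log units; beyond the scatter), so a second group with a carbon-only aromatic ring, 2-nitrophenyl, now falls on the weak side of compound 1 and compound 2, as 3-bromophenyl did. The step between compound 3 and compound 4 cannot be read, and the weak end of this series now rests on a shared limit: the limit of > 50000 nM in this assay, at which 2 of the 4 values shown sit.

The two limits leave 3-bromophenyl and 2-nitrophenyl unranked against each other. Going by these compounds, it also stays open whether a plain phenyl or a pyridin-4-yl group at this place would sit with compound 1 and compound 2 or at the limit.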